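Amination and N-substitution in a styryl sulfone cytotoxicity series

This account rests on a few compounds, and the source may have more. Where it says the series, first, only, none or still open, it means among the compounds named here.

Measured compounds:
compound 1 `COc1ccc(/C=C/S(=O)(=O)Cc2ccc(OC)c(N)c2)c(OC)c1` with 500 nM
compound 2 `COc1ccc(CS(=O)(=O)/C=C/c2c(OC)cc(OC)cc2OC)c(N)c1` with 25 nM
compound 3 `COc1cc(OC)c(/C=C/S(=O)(=O)Cc2ccc(OC)c(N)c2)c(OC)c1` with 4 nM

In a functional assay on DU-145 cells (Homo sapiens) for cytotoxicity, read by trypan blue exclusion, with a stated time of 96 h (on this read-out higher numbers stand for weaker inhibition and lower numbers for stronger inhibition), compound 3 gives the lowest number of the three. The step of a 130-fold lower number from compound 1 to compound 3 (2.10 log units; beyond the scatter) is large, and the step of a 6.3-fold lower number from compound 2 to compound 3 (0.80 log units; beyond the scatter) is modest. Compound 4 `COc1cc(OC)c(/C=C/S(=O)(=O)Cc2ccc(OC)c(NC(C(=O)O)c3ccc(Br)cc3)c2)c(OC)c1` carries (4-bromophenyl)(carboxy)methyl in place of hydrogen on a nitrogen on an aromatic ring. Neither measured step touches this nitrogen: one changes a ring substituent, the other the arrangement on the ring that bears the sulfonyl-bound carbon. Among the measured compounds shown here, no measured step therefore bears directly on the change to compound 4, and the expectation rests on the size of the entering group alone. Compound 4 is expected to give a somewhat higher number, estimated at 30 nM with a range of 4 nM to 300 nM, a step of a 7.5-fold higher number from compound 3 to compound 4 (0.88 log units; beyond the scatter).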

Compound 4, half-maximal inhibitory concentration: 300 nM
For compound 4 the middle estimate is 10-fold (1.00 log units) below the measured one; the range from low to high includes it.
By their numbers in this assay, from the lowest: compound 3; then compound 2; then compounds 4 and 1 (each within the scatter of the next).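

In this assay, placing (4-bromophenyl)(carboxy)methyl on the nitrogen gives a 75-fold higher number from compound 3 to compound 4 (1.88 log units; beyond the scatter) and provides the only reading at this nitrogen among these compounds. It shows that this position is sensitive to substitution, at least with this entering group, a point that the earlier changes elsewhere on the molecule could not address. Nothing available explains the loss. Which part of the entering group accounts for the step remains open, as does how a methyl group, an acetyl group or a methyl ester in place of the carboxylic acid would read here.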